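This account rests on a few compounds, and the source may have more. Where it says the series, first, only, none or still open, it means among the compounds named here.

Measured so far in a functional assay on Vero cells (Chlorocebus sabaeus) for inhibition; a lower number here means a stronger inhibitor, a higher number a weaker inhibitor:

compound 1 `Cc1cn([C@@H]2CS[C@@H](CO)O2)c(=O)nc1N`: > 100000 nM
compound 2 `Cc1cn([C@H]2CS[C@@H](CO)O2)c(=O)[nH]c1=O`: > 100000 nM
compound 3 `Cc1cn([C@H]2CS[C@@H](CO)O2)c(=O)nc1N`: > 100000 nM

None of these three values is a number; each is a limit of this assay. Compound 1 reaches only the limit > 100000 nM. Compound 2 likewise gives only the limit > 100000 nM. Compound 3 also stops at the limit > 100000 nM. Compound 2 therefore stands exactly where the whole set stands, at the limit of > 100000 nM in this assay, at which 3 of the 3 values shown sit, and nothing in these numbers separates it from the other two.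

For the measured compounds named here, the single measured step, a step that the two limits leave unreadable from compound 1 to compound 3, cannot be sized because the limit of > 100000 nM in this assay, at which 3 of the 3 values shown sit, holds at both of its ends. That step rests on (the fact that compounds 1 and 3 differ only in the configuration as drawn).

Compound 4 `Cc1cn([C@@H]2CS[C@@H](CO)O2)c(=O)[nH]c1=O` is the compound still to be measured. Its relation to compound 2 is the two compounds have the same atoms and bonds and differ only in configuration as drawn: 1 of 2 stereo elements differ; a stereocentre at a saturated ring carbon is drawn R in compound 2 and S in compound 4. Going by the values given here, this is the same kind of change as the one measured step, which gave no readable size. With every measured value sitting at the limit, the estimate for compound 4 in this assay is 100000 nM, expected to fall between 30000 nM and 300000 nM. The step from compound 2 to compound 4 is accordingly expected to be a number no higher from compound 2 to compound 4 (the limit leaves the size open).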

Compound 4, half-maximal inhibitory concentration: > 100000 nM
Compound 4 ended at the assay's limit; the forecaster's own chance of this, stated with the estimate: 85%; the middle value lies on the limit itself.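

Compound 2 and compound 4 both stop at a limit of this assay, not at a number, so the step between them cannot be read. As far as these compounds go, with all four compounds at that limit, how strongly any of them inhibits, and whether configuration matters, stays open.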